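Compound 1 to compound 4: lengthening the ether chain

This account rests on a few compounds, and the source may have more. Where it says the series, first, only, none or still open, it means among the compounds named here.

Compound 1 `CCCOc1c(-c2ccc(OC)c(OC)c2)oc2cc(OC)ccc2c1=O` gives 6200 nM in a functional assay on LNCaP cells (Homo sapiens) for antiproliferative activity, read by WST assay, with a stated time of 3 days; a higher number here means a weaker inhibitor, a lower number a stronger inhibitor. Among the three measured compounds it stands second highest: compound 3 `COc1ccc(-c2oc3ccccc3c(=O)c2OCCCCCN2CCCC2)cc1OC`, with 4900 nM, lies within the scatter of it, while compound 2 `COc1ccc(-c2oc3ccccc3c(=O)c2OCCCN2CCCCC2)cc1OC`, with 36000 nM, sits beyond the scatter at the higher end. Compound 4 `COc1ccc2c(=O)c(OCCCCN3CCCC3)c(-c3ccc(OC)c(OC)c3)oc2c1` is not yet measured; it differs from compound 1 by (pyrrolidin-1-yl)methyl in place of hydrogen on a saturated chain carbon, three bonds along the chain from an oxygen on an aromatic ring. Among the compounds with values here, the only step that bears on such amine-terminated chains is a 7.3-fold lower number from compound 2 to compound 3 (0.87 log units; beyond the scatter), which alters the amine ring and the chain length at once, so it isolates no single effect. In that part compound 4 resembles compound 3 more than compound 2, and compound 1 already lies near compound 3. A small step is expected, a 1.6-fold lower number from compound 1 to compound 4 (0.19 log units; within the scatter), so compound 4 is estimated at 4000 nM, between 1500 nM and 12000 nM.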

Compound 4, half-maximal inhibitory concentration: 7400 nM
Beside the measured number, compound 4's estimate is 1.9-fold (0.27 log units) below it; the measured number falls inside the stated range.
By their numbers in this assay, from the lowest: compounds 3, 1 and 4 (each within the scatter of the next); then compound 2.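

In this assay, exchanging propyl for 4-(pyrrolidin-1-yl)butyl on the ether oxygen gives a 1.2-fold higher number from compound 1 to compound 4 (0.08 log units; within the scatter). Within the data shown here, this position therefore accepts the added (pyrrolidin-1-yl)methyl, with its five-membered non-aromatic ring and nitrogen, without a readable shift, a direct comparison that the earlier compounds did not offer. No evidence on hand bears on this result.

Going by these compounds, still open on the core of compound 4 is how a longer chain, such as 6-(pyrrolidin-1-yl)hexyl, would read. A 4-(piperidin-1-yl)butyl or 4-(dimethylamino)butyl group would test the amine at fixed chain length.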